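The compounds below may be only part of what the source reports. "The series", "measured", "known", "first", "only" and "open" are said of these compounds alone.

Measured so far:
compound 1 `CC(Sc1nnc(-c2ccncc2)s1)C(=O)Nc1c(Cl)cccc1Cl`: > 50000 nM
compound 2 `O=C(CCSc1nnc(-c2ccncc2)s1)Nc1c(Cl)cccc1Cl`: 10300 nM
compound 3 `CC(Sc1nnc(-c2ccncc2)s1)C(=O)Nc1ccc(Cl)cc1`: > 50000 nM

Among the measured compounds shown here, in an ADME assay on BHK-21 cells (Mesocricetus auratus) for cytotoxicity, with a stated time of 3 days (on this read-out lower numbers stand for higher toxicity in this test and higher numbers for lower toxicity in this test), compound 2 gives 10300 nM, the only number among the three measured compounds. For compound 1 the reported value > 50000 nM is a limit of the assay, not a number. For compound 3 the reported value > 50000 nM is likewise a limit. For the measured compounds named here, the one single-point step, a step that the two limits leave unreadable from compound 1 to compound 3, sits under the limit of > 50000 nM in this assay, at which 2 of the 3 values shown sit, and gives no readable size. Going by the values given here, compound 4 `O=C(CCSc1nnc(-c2ccncc2)s1)Nc1ccccc1Cl` differs from compound 2 by hydrogen in place of chloro on an aromatic carbon; no measured pair covers this change. With no readable step in this assay, a move beyond the scatter is not expected, so the step of a 1.2-fold higher number from compound 2 to compound 4 (0.07 log units; within the scatter) is estimated as no change. Compound 4 is therefore expected near 12000 nM, between 4000 nM and 50000 nM.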

Compound 4, half-maximal cytotoxic concentration: > 50000 nM
Compound 4 was reported as a limit; the forecaster's own chance of this, stated with the estimate: 30%; middle value at least 4.1-fold (0.61 log units) from the limit.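

In this assay, among the compounds shown here, hydrogen in place of chloro on an aromatic carbon gives an at least 4.8-fold higher number from compound 2 to compound 4 (0.68 log units; beyond the scatter), the only readable step, showing that this position affects the read-out. Compound 4 gives > 50000 nM, which is a limit of the assay and not a number. The full size of the step therefore stays unknown, and most of the series sits at this ceiling: the limit of > 50000 nM in this assay, at which 3 of the 4 values shown sit.

Still open, on these data alone, is whether an amine or a methoxy group on this aromatic carbon would give a readable value in this assay. Also open, as far as these compounds go, is whether removing the remaining chloro of compound 4 changes anything.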